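A few compounds are considered here, and "the series" means these few. Any claim that something is new, unique, unknown or untested is made for them only; others in the source may bear on it.

Compound 1 `c1ccc(-c2ccncc2)c(OCC2=NCCN2)c1` — in a functional assay for activation of Alpha-1B adrenergic receptor (Homo sapiens), read by calcium flux (on this read-out higher numbers stand for an effect only at larger amounts of compound and lower numbers for an effect already at smaller amounts), compound 1 reaches only the assay limit < 100000 nM.
Compound 2 `Cc1cccc(-c2ccccc2OCC2=NCCN2)n1` — in this assay compound 2 likewise reaches only the assay limit < 100000 nM.
Compound 3 `c1csc(-c2ccccc2OCC2=NCCN2)c1` — in this assay compound 3 gives 3.98 nM.

For the measured compounds named here, compound 3 holds the only real number; the other two values are limits, as the limit of < 100000 nM in this assay, at which 2 of the 3 values shown sit, shows. Going by the values given here, the single one-place step, a step that the limit leaves unreadable from compound 1 to compound 3, cannot be sized, since compound 1 sits at the limit; it shows only that the thiophen-2-yl compound is active where the pyridin-4-yl compound is not read.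

Compound 4 `Cc1csc(-c2ccccc2OCC2=NCCN2)n1` is the next one to be measured in this assay. The change from compound 3 is 4-methyl-1,3-thiazol-2-yl in place of thiophen-2-yl on an aromatic carbon. Among the compounds with values here, no measured step sets the size of this change: the one step that is known runs from a limit and cannot be read, and the step from compound 3 to compound 2 is also left unreadable by the limit of compound 2. The expectation therefore rests on compound 3 alone, with wide uncertainty. A modest loss is expected, a 10-fold higher number from compound 3 to compound 4 (1.00 log units; beyond the scatter), because compound 3 gives 3.98 nM and the change keeps a five-membered aromatic ring at the same place. For compound 4 the estimate in this assay is 40 nM, with a range from 4 nM to 400 nM.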

Compound 4, half-maximal effective concentration: < 100000 nM
Compound 4: no number, only a limit (the forecaster's own chance of this, stated with the estimate: 15%); the middle value is on the limit's open side.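

In this assay compound 4 gives < 100000 nM, which is a limit and not a number. The steps linking compound 4 to compound 3 and to compound 1 therefore cannot be read, and the series stays mostly at the limit: the limit of < 100000 nM in this assay, at which 3 of the 4 values shown sit.

The compounds shown leave open how large a change in potency follows when thiophen-2-yl is replaced on the shared core.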